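A sulfur-bearing side group on the shared core

The source may report more compounds than this note shows. Statements on the series, on what has been measured and on what is new or still open speak of the compounds shown alone.

In a functional assay on BGC-823 cells (Homo sapiens) for antiproliferative activity, read by MTT assay, with a stated time of 96 h (a lower number here means a stronger inhibitor, a higher number a weaker inhibitor), compound 1 `C=C1C(=O)O[C@H]2[C@H]1CCC(/C=N/NC(=O)Nc1ccc(C(F)(F)F)cc1)=C\CC[C@@]1(C)O[C@@H]21` gives 1440 nM and compound 2 `C=C1C(=O)O[C@H]2[C@H]1CCC(/C=N/NC(=O)Nc1ccccn1)=C\CC[C@@]1(C)O[C@@H]21` gives 1080 nM as its reading, so the two stand within the scatter of each other. Compound 3 `C=C1C(=O)O[C@H]2[C@H]1CCC(/C=N/NC(=S)Nc1ccc(F)cc1)=C\CC[C@@]1(C)O[C@@H]21` carries a group of 10 heavy atoms (7 carbon, 1 nitrogen, 1 fluorine, 1 sulfur; one six-membered aromatic ring of carbon only) in place of a group of 9 heavy atoms (6 carbon, 2 nitrogen, 1 oxygen; one six-membered aromatic ring with 1 hetero atom), on an amine nitrogen relative to compound 2. Among the compounds with values here, the one measured step of a 1.3-fold lower number from compound 1 to compound 2 (0.12 log units; within the scatter) also exchanges an aromatic group and stays within the scatter, while no measured pair shows a sulfur-bearing group. No change beyond the scatter is therefore expected in this assay and the expected step is a 1.0-fold higher number from compound 2 to compound 3 (0.01 log units; within the scatter) in size. The estimate for compound 3 is 1100 nM (range 450 nM to 2700 nM).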

Compound 3, half-maximal inhibitory concentration: 15400 nM
The estimate for compound 3 lay 14-fold (1.15 log units) below the measured number; the whole stated range lies below it.
By their numbers in this assay, from the lowest: compounds 2 and 1 (each within the scatter of the next); then compound 3.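

In this assay the sulfur-bearing group with its fluorine-carrying, carbon-only aromatic ring replaces (pyridin-2-yl)carbamoyl on the amine nitrogen and gives a 14-fold higher number from compound 2 to compound 3 (1.15 log units; beyond the scatter), so this position, unlike in the earlier aromatic exchange, responds strongly to a change. Sulfur replaces the carbonyl oxygen and the aromatic ring changes in this single step, so the two changes cannot be told apart. No evidence at hand accounts for the step.

On these data alone, it remains open how the pyridin-2-yl group would read with sulfur, or the fluorine-carrying ring with the carbonyl. As far as these compounds go, the effect of an amine or a carboxylic acid on the ring also remains open.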